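Series notes: aryl exchange on the saturated ring carbon

A few compounds are considered here, and "the series" means these few. Any claim that something is new, unique, unknown or untested is made for them only; others in the source may bear on it.

Measured so far:
compound 1 `COc1ccc2ccc(=O)oc2c1C1=NN(C(N)=O)C(c2cccs2)C1`: in a functional assay on HepG2 cells (Homo sapiens) for cytotoxicity, read by MTT assay, with a stated time of 72 h (on this read-out lower numbers stand for stronger inhibition and higher numbers for weaker inhibition), compound 1 gives 26 nM
compound 2 `COc1ccc2ccc(=O)oc2c1C1=NN(C(N)=O)C(c2ccc(C(F)(F)F)cc2)C1`: in this assay compound 2 gives 96 nM
compound 3 `COc1ccc2ccc(=O)oc2c1C1=NN(c2ccccc2)C(c2cccs2)C1`: in this assay compound 3 gives 15 nM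

The change from compound 1 to compound 2 is 4-(trifluoromethyl)phenyl in place of thiophen-2-yl on a saturated ring carbon and gave a 3.7-fold higher number from compound 1 to compound 2 (0.57 log units; beyond the scatter). The two cores differ by phenyl in place of carbamoyl on an amine nitrogen in a ring, with a 1.7-fold lower number from compound 1 to compound 3 (0.24 log units; within the scatter). Compound 4 `COc1ccc2ccc(=O)oc2c1C1=NN(c2ccccc2)C(c2ccc(C(F)(F)F)cc2)C1` differs from compound 3 by 4-(trifluoromethyl)phenyl in place of thiophen-2-yl on a saturated ring carbon. The place lines are not identical: in compound 1 the saturated ring carbon is next to the ring atom that bears a carbamoyl group (3 heavy atoms), in compound 3 next to the ring atom that bears a phenyl group (6 heavy atoms), so this is the same kind of change rather than the same one. In this assay a step of a 3.7-fold higher number from compound 3 to compound 4 (0.56 log units; beyond the scatter) is expected for compound 4, resting on a 3.7-fold higher number from compound 1 to compound 2 (0.57 log units; beyond the scatter) seen for compound 1. Compound 4 is thus estimated at 55 nM, between 25 nM and 130 nM.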

Compound 4, half-maximal inhibitory concentration: 38 nM
The estimate for compound 4 lay 1.4-fold (0.16 log units) above the measured number; low and high end bracket the measured number.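

In this assay, the exchange of thiophen-2-yl for 4-(trifluoromethyl)phenyl on the saturated ring carbon carries over between cores in direction, giving a 2.5-fold higher number from compound 3 to compound 4 (0.40 log units; beyond the scatter), and the two steps do not differ beyond the scatter: the same change on two cores in this assay, a 3.7-fold higher number (0.57 log units; beyond the scatter) from compound 1 to compound 2 and a 2.5-fold higher number (0.40 log units; beyond the scatter) from compound 3 to compound 4, 1.5-fold (0.16 log units) apart, within the scatter of two such steps. Among the compounds shown here, the exchange of carbamoyl for phenyl on the amine nitrogen in the ring reads the same way, giving a 2.5-fold lower number from compound 2 to compound 4 (0.40 log units; beyond the scatter), although only this step lies beyond the scatter: the same change on two cores in this assay, a 1.7-fold lower number (0.24 log units; within the scatter) from compound 1 to compound 3 and a 2.5-fold lower number (0.40 log units; beyond the scatter) from compound 2 to compound 4, 1.5-fold (0.16 log units) apart, within the scatter of two such steps. This agreement rests on a single square of four compounds, so it shows that the two changes transfer here, not that they would transfer to other groups or cores.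

The compounds shown leave open whether the steps hold with an amine or a carboxylic acid on the saturated ring carbon. Also open, as far as these compounds go, is whether they hold with a longer chain on the amine nitrogen in the ring.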